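Changing the Phenyl Group on an Aromatic Nitrogen

The source may report more compounds than this note shows. Statements on the series, on what has been measured and on what is new or still open speak of the compounds shown alone.

Compound 1, `N#CC1=C(N)Oc2c(c3nc4ccccc4nc3c3ccccc23)C12C(=O)N(Cc1cnnn1-c1ccc(Br)cc1)c1ccccc12`, gives > 50000 nM in an ADME assay on HUVEC cells (Homo sapiens) for antiproliferative activity, read by MTT assay, with a stated time of 48 h (a lower number here means a stronger inhibitor, a higher number a weaker inhibitor), which is a limit of the assay and not a number. Compound 2, `COc1ccc(-n2nncc2CN2C(=O)C3(C(C#N)=C(N)Oc4c(N)cc5nc6ccccc6nc5c43)c3ccccc32)cc1`, gives > 50000 nM in this assay, again a limit of the assay rather than a number.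

Within the data shown here, compound 2 therefore stands only at a limit: no inhibition strong enough to yield a number was seen, and the one further value shown is a limit as well, since (the limit of > 50000 nM in this assay, at which 2 of the 2 values shown sit). Nothing in these two values separates the compounds or points in any direction.

Compound 3, `Cc1ccc(-n2nncc2CN2C(=O)C3(C(C#N)=C(N)Oc4c(N)cc5nc6ccccc6nc5c43)c3ccccc32)cc1Cl`, differs from compound 2 in one place: 3-chloro-4-methylphenyl in place of 4-methoxyphenyl on an aromatic nitrogen. Among the measured compounds shown here, no measured step between two compounds is available here, so there is no measured precedent for what such a swap does in this assay. Given that compound 2 sits at > 50000 nM, the expectation is a step of no size beyond the scatter, with compound 3 most likely again reported only as a limit. The step that the limit leaves unreadable from compound 2 to compound 3 is expected to be essentially flat. Compound 3 is thus estimated at 60000 nM, with a range from 15000 nM to 250000 nM.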

Compound 3, half-maximal inhibitory concentration: > 50000 nM
Compound 3 gave a limit, no number (the forecaster's own chance of this, stated with the estimate: 85%); the middle value lies beyond the limit too.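

In this assay compound 3 gives > 50000 nM, which is a limit of the assay and not a number. Compound 2 also stands at a limit, so no step between compound 2 and compound 3 can be read: the limit of > 50000 nM in this assay, at which 3 of the 3 values shown sit.

The compounds shown leave open whether any change to the group on the aromatic nitrogen affects activity in this assay.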